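This account rests on a few compounds, and the source may have more. Where it says the series, first, only, none or still open, it means among the compounds named here.

Measured compounds:
compound 1 `COc1ncnc2c1c(I)cn2[C@@H]1O[C@H](CO)[C@@H](O)[C@H]1O` — 14800 nM
compound 2 `Nc1nc(N)c2c(-c3ccoc3)cn([C@@H]3O[C@H](CO)[C@@H](O)[C@H]3O)c2n1` — > 20000 nM, a limit
compound 3 `O=c1[nH]cnc2c1c(-c1cc3ccccc3o1)cn2[C@@H]1O[C@H](CO)[C@@H](O)[C@H]1O` — > 20000 nM, a limit

All three were tested in a functional assay on K562 cells (Homo sapiens), read by MTT assay, with a stated time of 72 h; a lower number here means a stronger inhibitor, a higher number a weaker inhibitor. Compound 1 is the only one of the three for which a number was obtained; in this assay compound 1 gives 14800 nM. For compound 2 the result is only a limit, > 20000 nM. For compound 3 the result is likewise only a limit, > 20000 nM. Both of those rest on (the limit of > 20000 nM in this assay, at which 2 of the 3 values shown sit), so no ordering among the three can be drawn beyond the fact that compound 1 alone produced a measurable value.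

Compound 4 `COc1ncnc2c1c(-c1ccco1)cn2[C@@H]1O[C@H](CO)[C@@H](O)[C@H]1O` is not yet measured. It differs from compound 1 in one place: furan-2-yl in place of iodo on an aromatic carbon. The shared core and the sugar part are unchanged.

Among the compounds with values here, no measured pair shows what this kind of exchange does, so the expectation for the step rests only on compound 1 and on the two limits. Given that compound 1 is already a weak inhibitor and that two of three values sit at the limit of > 20000 nM in this assay, at which 2 of the 3 values shown sit, the step of a 1.7-fold higher number from compound 1 to compound 4 (0.23 log units; within the scatter) is expected to lean toward a weaker inhibitor or no change beyond the scatter. Compound 4 is therefore estimated at 25000 nM, with a range from 8000 nM to 80000 nM, and a result reported only as a limit is quite possible.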

Compound 4, half-maximal inhibitory concentration: 380 nM
Beside the measured number, compound 4's estimate is 66-fold (1.82 log units) above it; measured number outside the range, below it.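

In this assay, putting furan-2-yl in place of iodo on this aromatic carbon gives a 39-fold lower number from compound 1 to compound 4 (1.59 log units; beyond the scatter), a step well beyond the scatter. This shows that the group at this one place can strongly change the reading in this cell assay: the shared core and the sugar part are the same in both compounds, and compound 4, with its five-membered aromatic ring, is clearly the stronger inhibitor of this pair. No measurement shown gives a reason for the size of this step.

This single pair cannot separate the effect of gaining the furan-2-yl ring from that of losing the iodo group, and compounds 2 and 3 differ from compound 4 in more than one place, so they do not settle the question. On these data alone, it also remains open whether a thiophen-2-yl or phenyl ring, a small chain such as methyl, or an amine at this same carbon would give a number close to that of compound 4 or close to that of compound 1.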